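Swapping the phenylsulfanyl group in a purine-type antiproliferative series

This account rests on a few compounds, and the source may have more. Where it says the series, first, only, none or still open, it means among the compounds named here.

Measured compounds:
- compound 1 `CN1CCN(c2ccc(Nc3ncc4nc(Sc5ccccc5)n(C5CCOCC5)c4n3)cc2)CC1`: 42.6 nM
- compound 2 `CC(C)n1c(Sc2ccccc2)nc2cnc(Nc3ccc(N4CCN(C)CC4)cc3)nc21`: 290 nM

In a functional assay on HCC827 cells (Homo sapiens) for antiproliferative activity, read by MTT assay, with a stated time of 72 h (a lower number here means a stronger inhibitor, a higher number a weaker inhibitor), compound 1 gives 42.6 nM, the lowest of the two numbers measured; the nearest is compound 2, which differs from it in one place and shows a 6.8-fold higher number from compound 1 to compound 2 (0.83 log units; beyond the scatter). That step concerns the group on the aromatic nitrogen and says nothing about the group under study here.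

Compound 3 `CN1CCN(c2ccc(Nc3ncc4nc([S+]([O-])Cc5cccnc5)n(C5CCOCC5)c4n3)cc2)CC1` keeps the oxan-4-yl group and the rest of the shared core of compound 1 but carries a different group on the aromatic carbon: a group of 9 heavy atoms (6 carbon, 1 nitrogen, 1 oxygen, 1 sulfur; one six-membered aromatic ring with 1 hetero atom) in place of a group of 7 heavy atoms (6 carbon, 1 sulfur; one six-membered aromatic ring of carbon only), on an aromatic carbon. For the measured compounds named here, no measured pair shows this change, so there is no step to lean on, and the expectation rests on the values of compound 1 alone with a wide range.

Compound 3 is expected to give 90 nM (range 25 nM to 350 nM) in this assay. This estimate means a step of a 2.1-fold higher number from compound 1 to compound 3 (0.32 log units; beyond the scatter), expected to be a modest weakening at most.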

Compound 3, half-maximal inhibitory concentration: > 10000 nM
Compound 3: no number, only a limit; the forecaster's own chance of this, stated with the estimate: 5%; middle value at least 110-fold (2.04 log units) from the limit.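

This is the first change shown at the aromatic carbon between two ring nitrogen atoms, and in this assay it gives an at least 230-fold higher number from compound 1 to compound 3 (2.37 log units; beyond the scatter), so activity here depends strongly on the group carried, more than the earlier step on the aromatic nitrogen could suggest. The entry for compound 3 is a limit of the assay and not a number: the limit of > 10000 nM in this assay, at which 1 of the 3 values shown sits. The entering group differs from phenylsulfanyl in several ways at once, including a hetero atom in the ring and an extra oxygen, so this single step cannot assign the drop to any one of them.

The compounds shown leave open which of these parts matters most. A phenylsulfinyl group, a benzylsulfanyl group or a simple amine at this carbon would help to separate them.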